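Methoxy for Methyl on a Fused Aromatic Ring

A few compounds are considered here, and "the series" means these few. Any claim that something is new, unique, unknown or untested is made for them only; others in the source may bear on it.

Of the compounds shown here, two have been measured in a functional assay on HBL-100 cells (Homo sapiens) for inhibition, read by sulforhodamine B assay, with a stated time of 48 h; on this read-out lower numbers stand for stronger inhibition of growth and higher numbers for weaker inhibition of growth. Compound 1 `COC(=O)[C@@]1(C)CCC=C2[C@@H]1CC[C@@H](C)[C@]2(C)Cc1c[nH]c2ccc(F)cc12` gives 4800 nM in this assay. Compound 2 `COC(=O)[C@@]1(C)CC[C@@H]2C3=C1CC[C@@H](C)[C@]3(C)C[C@@H]1c3cc(C)ccc3N[C@H]21` gives 15000 nM, the higher of the two numbers, and the gap between compound 1 and compound 2 lies beyond the usual scatter of this assay. Compound 3 `COC(=O)[C@@]1(C)CC[C@@H]2C3=C1CC[C@@H](C)[C@]3(C)C[C@@H]1c3cc(OC)ccc3N[C@H]21` has not yet been measured. It differs from compound 2 in one place: methoxy in place of methyl on an aromatic carbon. Going by the values given here, no measured pair shows this exchange on its own, so the step has no direct precedent among the known compounds. Since the exchange keeps the size of the group nearly unchanged, the step is expected to stay within the scatter, as no change at the digits printed from compound 2 to compound 3 (within the scatter). Compound 3 is therefore estimated at 15000 nM in this assay, with a range from 6000 nM to 40000 nM.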

Compound 3, concentration for 50% growth inhibition: 15000 nM
For compound 3 middle estimate and measured number coincide at the digits printed; the measured number falls inside the stated range.
By their numbers in this assay, from the lowest: compound 1; then compounds 2 and 3 (each within the scatter of the next).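

Going by these compounds alone, the pair gives the first direct reading of this exchange at this aromatic carbon: in this assay methoxy in place of methyl gives no change at the digits printed from compound 2 to compound 3 (within the scatter) and so sets a second compound with this core at the same printed level. At this position, the added oxygen, counted as one hydrogen-bond acceptor, and the extra heavy atom leave the read-out within the scatter. Nothing available here accounts for this outcome.

The compounds shown leave open how this carbon would respond to groups of another kind, such as an amine, a carboxylic acid or a longer chain like butoxy. They also leave open whether the same exchange of methyl for methoxy would read alike on the other carbons of this aromatic ring.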